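This account rests on a few compounds, and the source may have more. Where it says the series, first, only, none or still open, it means among the compounds named here.

In a functional assay on cells (KATO III cell, Homo sapiens) for antiproliferative activity, read by MTT assay (on this read-out higher numbers stand for weaker inhibition and lower numbers for stronger inhibition), compound 1 `O=C1NC(c2ccccc2)CN1S(=O)(=O)c1ccc2c(c1)CCCN2` gives > 20000 nM, which is a limit of the assay and not a number. Within the data shown here, compound 2 `CCCOC(=O)N1CCCc2cc(S(=O)(=O)N3CC(c4ccccc4)NC3=O)ccc21`, which carries a propoxycarbonyl group, gives 3300 nM, the only exact number so far. Among the measured compounds shown here, the one measured step is an at least 6.0-fold lower number from compound 1 to compound 2 (0.78 log units; beyond the scatter). Compound 3 `CC(C)COC(=O)N1CCCc2cc(S(=O)(=O)N3CC(c4ccccc4)NC3=O)ccc21` differs from compound 2 by methyl in place of hydrogen on a saturated chain carbon bound to two saturated chain carbons, which turns propoxy into isobutoxy. That measured step added the whole propoxycarbonyl group, whereas this change only alters its chain, so no shift beyond the scatter is expected. The estimated step is a 1.1-fold lower number from compound 2 to compound 3 (0.04 log units; within the scatter). For compound 3, the expected value is 3000 nM, with an estimated range of 1200 nM to 7500 nM.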

Compound 3, half-maximal inhibitory concentration: 2750 nM
For compound 3 the middle estimate is 1.1-fold (0.04 log units) above the measured one; low and high end bracket the measured number.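

In this assay, the methyl that turns propoxy into isobutoxy gives a 1.2-fold lower number from compound 2 to compound 3 (0.08 log units; within the scatter), so this chain tolerates this branch without a shift that can be told from the scatter. The isobutoxycarbonyl group also goes with a lower number than hydrogen on that nitrogen, an at least 7.2-fold lower number from compound 1 to compound 3 (0.86 log units; beyond the scatter), which shows that the earlier step is not unique to propoxycarbonyl. That step starts from a limit of the assay and not a number: the limit of > 20000 nM in this assay, at which 1 of the 3 values shown sits.

The compounds shown leave open whether a much longer chain, or an amine in place of propoxy, would keep, lower or raise the number.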